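Bromo for Cyano on a Glycine Transporter Amide

The source may report more compounds than this note shows. Statements on the series, on what has been measured and on what is new or still open speak of the compounds shown alone.

Compound 1 `COc1cc(C(F)(F)F)cc(C(F)(F)F)c1C(=O)NC1(c2ccccc2)CCCN(S(C)(=O)=O)C1` and compound 2 `CN1CCCC(NC(=O)c2ccc(C(F)(F)F)cc2C#N)(c2ccccc2)C1` were both tested in an assay on cells for inhibition of sodium- and chloride-dependent glycine transporter 1 (Homo sapiens); on this read-out higher numbers stand for an effect only at larger amounts of compound and lower numbers for an effect already at smaller amounts. In this assay compound 1 is reported only as a limit, > 10000 nM. Compound 2 likewise reaches only a limit in this assay, > 10000 nM. Compound 2 thus stands at the limit of > 10000 nM in this assay, at which 2 of the 2 values shown sit, with no number to place it. Compound 3 `CN1CCCC(NC(=O)c2ccc(C(F)(F)F)cc2Br)(c2ccccc2)C1` differs from compound 2 by bromo in place of cyano on an aromatic carbon. Without a measured step to lean on, the expected change in this assay is a step that the limit leaves unreadable from compound 2 to compound 3, none beyond the scatter. Compound 3 is therefore estimated at 15000 nM, within a range from 5000 nM to 50000 nM.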

Compound 3, half-maximal effective concentration: 300 nM
Compound 3: middle estimate off by 50-fold (1.70 log units), on the high side; measured number outside the range, below it.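

Within the data shown here, on the aromatic carbon ortho to a large group, bromo in place of cyano gives an at least 33-fold lower number from compound 2 to compound 3 (1.52 log units; beyond the scatter) in this assay and thereby shows that this position responds to the group it carries, which the earlier compounds, both reported only as limits, could not show. Among these compounds, compound 3 is the only compound here with a number rather than a limit, and it differs from compound 2 in this one place.

From the compounds shown here alone, whether chloro, iodo or methyl on this carbon would give a similar number remains open. The full size of the step also remains open, because compound 2 gives only a limit: the limit of > 10000 nM in this assay, at which 2 of the 3 values shown sit.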